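The source may hold more compounds than are shown below. What is called first, only, known or untested is meant among the compounds shown, and "the series" means these compounds.

Working notes on the series. All members share one core carrying an aryl sulfonamide, the aryl on the sulfonamide nitrogen being the varied part. Compound 1 `O=C1/C(=C/c2coc3ccccc3c2=O)N=C(c2ccc(Cl)cc2)N1c1ccc(S(=O)(=O)Nc2nccs2)cc1` bears a 1,3-thiazol-2-yl there. In a functional assay on A549 cells (Homo sapiens) for cytotoxicity, read by sulforhodamine B assay, with a stated time of 72 h (a higher number here means a weaker inhibitor, a lower number a stronger inhibitor), compound 1 reaches only a limit, > 100000 nM. Compound 2 `Cc1cc(NS(=O)(=O)c2ccc(N3C(=O)/C(=C/c4coc5ccccc5c4=O)N=C3c3ccc(Cl)cc3)cc2)no1` carries 5-methyl-1,2-oxazol-3-yl in place of that group. In this assay compound 2 is likewise reported as a limit, > 100000 nM. Compound 3 `O=C1/C(=C/c2coc3ccccc3c2=O)N=C(c2ccc(Cl)cc2)N1c1ccc(S(=O)(=O)Nc2ccccn2)cc1` has pyridin-2-yl on the sulfonamide nitrogen. In this assay compound 3 again gives a limit, > 100000 nM. Compound 3 thus stands with the other two at the limit of > 100000 nM in this assay, at which 3 of the 3 values shown sit, and the steps a step that the two limits leave unreadable from compound 1 to compound 3 and a step that the two limits leave unreadable from compound 2 to compound 3, like a step that the two limits leave unreadable from compound 1 to compound 2, cannot be sized.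

Compound 4 `O=C1/C(=C/c2coc3ccccc3c2=O)N=C(c2ccccc2)N1c1ccc(S(=O)(=O)Nc2ccccn2)cc1` differs from compound 3 by hydrogen in place of chloro on an aromatic carbon. Going by the values given here, no measured step touches this position, and the three measured steps all sit at the limit and give no direction. The expectation rests on the limit of > 100000 nM in this assay, at which 3 of the 3 values shown sit, alone, with nothing to suggest a readable move. The step implied by this expectation is a step that the limit leaves unreadable from compound 3 to compound 4. Compound 4 is therefore estimated at 150000 nM, in the range 40000 nM to 500000 nM, most likely reported again as a limit rather than a number.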

Compound 4, half-maximal inhibitory concentration: > 100000 nM
Compound 4 ended at the assay's limit; the forecaster's own chance of this, stated with the estimate: 85%; the middle value does not contradict the limit.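

In this assay compound 4 gives > 100000 nM, a limit, as compound 3 does, so no new step can be read between compound 3 and compound 4. The compounds shown stand together: the limit of > 100000 nM in this assay, at which 4 of the 4 values shown sit.

The compounds shown leave open how the sulfonamide aryl group or the 4-chlorophenyl group bears on this assay, as none gives a number rather than a limit.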